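A few compounds are considered here, and "the series" means these few. Any claim that something is new, unique, unknown or untested is made for them only; others in the source may bear on it.

Of the compounds shown here, three built on one shared core have been measured in a functional assay on MKN-28 cells (Homo sapiens) for cytotoxicity, read by MTT assay (a higher number here means a weaker inhibitor, a lower number a stronger inhibitor), and a fourth has not.

Compound 1 is `C=C1C(=O)[C@]23C[C@@]1(I)CC[C@H]2[C@@]12C=CC(=O)[C@](C)(C(=O)O1)[C@H]2[C@@H]3C(=O)OC`, and in this assay compound 1 gives 6700 nM. Compound 2 is `C=C1C(=O)[C@]23C[C@@]1(I)CC[C@H]2[C@@]12C=CC(=O)[C@](C)(C(=O)O1)[C@H]2[C@@H]3C(=O)OCc1ccccc1`; it differs from compound 1 by phenyl in place of hydrogen on a saturated chain carbon bound to an oxygen next to a carbonyl group, and in this assay compound 2 gives 3000 nM, which is a 2.2-fold lower number from compound 1 to compound 2 (0.35 log units; beyond the scatter). Compound 3 is `C=C1C(=O)[C@]23C[C@@]1(OC)CC[C@H]2[C@@]12C=CC(=O)[C@](C)(C(=O)O1)[C@H]2[C@@H]3C(=O)OC`; its core differs from the core of compound 1 by methoxy in place of iodo on a saturated ring carbon, and in this assay compound 3 gives 3400 nM, a change of a 2.0-fold lower number from compound 1 to compound 3 (0.29 log units; within the scatter).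

Compound 4 is `C=C1C(=O)[C@]23C[C@@]1(OC)CC[C@H]2[C@@]12C=CC(=O)[C@](C)(C(=O)O1)[C@H]2[C@@H]3C(=O)OCc1ccccc1`. It stands to compound 3 exactly as compound 2 stands to compound 1: the difference is phenyl in place of hydrogen on a saturated chain carbon bound to an oxygen next to a carbonyl group, at the same place as before, so the same change appears in two pairs among these compounds. Within the data shown here, the only measured example of this change is the step from compound 1 to compound 2, which was modest and just beyond the usual scatter.

Because a 2.2-fold lower number from compound 1 to compound 2 (0.35 log units; beyond the scatter) was seen on the core of compound 1, a step of roughly the same size is expected here, namely a 2.0-fold lower number from compound 3 to compound 4 (0.30 log units; within the scatter). That expectation rests on a single measured pair and on the closeness of compounds 2 and 3, whose values sit within the scatter of each other. Compound 4 is therefore estimated at 1700 nM in this assay, with the likely range running from 800 nM to 3500 nM.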

Compound 4, half-maximal inhibitory concentration: 800 nM
Estimate against measurement, compound 4: 2.1-fold (0.33 log units) above, within the range that was stated.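

In this assay the change from methyl to benzyl on the ester gives a 4.3-fold lower number from compound 3 to compound 4 (0.63 log units; beyond the scatter), and it points the same way on both cores, with a gap between the two steps that is no larger than repeated measurements could produce: the same change on two cores in this assay, a 2.2-fold lower number (0.35 log units; beyond the scatter) from compound 1 to compound 2 and a 4.3-fold lower number (0.63 log units; beyond the scatter) from compound 3 to compound 4, 1.9-fold (0.28 log units) apart, within the scatter of two such steps. The change from iodo to methoxy on the saturated ring carbon, now read on the benzyl ester, gives a 3.8-fold lower number from compound 2 to compound 4 (0.57 log units; beyond the scatter), and it too agrees with its earlier step: the same change on two cores in this assay, a 2.0-fold lower number (0.29 log units; within the scatter) from compound 1 to compound 3 and a 3.8-fold lower number (0.57 log units; beyond the scatter) from compound 2 to compound 4, 1.9-fold (0.28 log units) apart, within the scatter of two such steps. So within these four compounds each change carries from one core to the other in direction, and the data give no firm sign that its size depends on the core, although the larger second steps cannot be called a real difference or ruled out as one, and two pairs per change say nothing about cores beyond these.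

The compounds shown leave open whether a longer chain, a substituted benzyl or a carboxylic acid in place of the ester group would lower the number further. They also leave open what an amine or a plain hydrogen would do in place of the methoxy or iodo on that ring carbon.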